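The compounds below may be only part of what the source reports. "The series", "measured", "known", "first", "only" and "open" are said of these compounds alone.

Measured so far:
compound 1, `Fc1ccc2ncc(-c3nn[nH]n3)cc2c1`: 50 mg/kg
compound 2, `Cc1cc([N+](=O)[O-])c2cc(-c3nn[nH]n3)cnc2c1C`: 25 mg/kg
compound 3, `O=c1c(-c2nn[nH]n2)c[nH]c2ccc(F)cc12`: > 20 mg/kg

In a functional assay on the whole organism (strain Sprague-Dawley) for inhibition, with Rattus norvegicus as the target (on this read-out lower numbers stand for an effect already at smaller amounts and higher numbers for an effect only at larger amounts of compound), compound 2 gives 25 mg/kg. Compound 1 gives 50 mg/kg in this assay, and the two numbers lie within the usual scatter of each other, so the data do not tell the two compounds apart. For compound 3 this assay reports only a limit, not a number: > 20 mg/kg. That limit is the limit of > 20 mg/kg in this assay, at which 1 of the 3 values shown sits.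

Compound 4, `Cc1ccc2cc(-c3nn[nH]n3)cnc2c1C`, has not yet been measured in this assay. It differs from compound 2 in one place: hydrogen in place of nitro on an aromatic carbon. Among the measured compounds shown here, no pair of compounds measured so far differs by such a change, so the size of the step cannot be read from the numbers in hand. Taking the nitro away is a small change in the count of heavy atoms, and the step is expected to be small, more likely toward a higher number than a lower one, and possibly no larger than the scatter. The step from compound 2 to compound 4 in this assay is expected to be a 1.6-fold higher number from compound 2 to compound 4 (0.20 log units; within the scatter). Compound 4 is therefore estimated at 40 mg/kg in this assay, with a range from 15 mg/kg to 100 mg/kg.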

Compound 4, minimum effective dose: 25 mg/kg
For compound 4 the middle estimate is 1.6-fold (0.20 log units) above the measured one, and the stated range covers the measured number.
By their numbers in this assay, from the lowest: compounds 2, 4 and 1 (each within the scatter of the next).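

Replacing the nitro group with hydrogen on this aromatic carbon, in a ring that also carries two methyl groups, gives no change at the digits printed from compound 2 to compound 4 (within the scatter) in this assay. Among the compounds shown here, until now no two measured compounds differed in one place, so this pair gives the first direct reading of a single change: on this read-out, the nitro group and its 3 heavy atoms can be removed from this position with no difference that the data can detect. No measured property in hand bears on why the swap leaves the number in place.

Going by these compounds, the result rests on one pair and only two occupants of this position, nitro and hydrogen, so it remains open whether an amine, a carboxylic acid or a methoxy group would also leave the number in place. On these data alone, it is equally open whether hydrogen could replace nitro with the same outcome on a core without the two methyl groups, since a single pair cannot show how far the finding extends.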